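Swapping the pendant aryl group: naphthalene to thiophene

This account rests on a few compounds, and the source may have more. Where it says the series, first, only, none or still open, it means among the compounds named here.

Compound 1 `CC(=O)OC[C@H]1O[C@@H](n2cc(CN3C(=O)/C(=C/c4ccccc4)c4ccccc43)nn2)[C@H](OC(C)=O)[C@@H](OC(C)=O)[C@@H]1OC(C)=O` gives 37100 nM in a functional assay on HeLa cells (Homo sapiens) for cytotoxicity, read by sulforhodamine B assay, with a stated time of 48 h; on this read-out higher numbers stand for weaker inhibition and lower numbers for stronger inhibition.
Compound 2 `CC(=O)OC[C@H]1O[C@@H](n2cc(CN3C(=O)/C(=C/c4ccc5ccccc5c4)c4ccccc43)nn2)[C@H](OC(C)=O)[C@@H](OC(C)=O)[C@@H]1OC(C)=O` gives > 100000 nM in this assay.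

For compound 2 that figure is a limit of the assay rather than a number (the limit of > 100000 nM in this assay, at which 1 of the 2 values shown sits). Compound 3 `CC(=O)OC[C@H]1O[C@@H](n2cc(CN3C(=O)/C(=C/c4cccs4)c4ccccc43)nn2)[C@H](OC(C)=O)[C@@H](OC(C)=O)[C@@H]1OC(C)=O` differs from it by thiophen-2-yl in place of naphthalen-2-yl on a double-bonded chain carbon bound to a double-bonded ring carbon. Among the compounds with values here, the only measured step at this position is an at least 2.6-fold higher number from compound 1 to compound 2 (0.43 log units; beyond the scatter), where the larger ring gave the weaker result. With a smaller ring entering, a return toward the level of compound 1 is expected, so the step is expected to be an at least 2.5-fold lower number from compound 2 to compound 3 (0.39 log units; beyond the scatter). Compound 3 is thus estimated at 40000 nM, within 15000 nM to 120000 nM.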

Compound 3, half-maximal inhibitory concentration: 36900 nM
For compound 3 the middle estimate is 1.1-fold (0.04 log units) above the measured one, within the range that was stated.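

Thiophen-2-yl in place of naphthalen-2-yl gives an at least 2.7-fold lower number from compound 2 to compound 3 (0.43 log units; beyond the scatter), so the weaker result seen with naphthalen-2-yl does not carry over to this five-membered ring. Compared with phenyl, thiophen-2-yl gives a 1.0-fold lower number from compound 1 to compound 3 (0.00 log units; within the scatter), so these two groups cannot be told apart in this assay, and only naphthalen-2-yl stands out among the three. The figure for compound 2 is a limit of the assay, not a number: the limit of > 100000 nM in this assay, at which 1 of the 3 values shown sits.

Still open, on these data alone, is whether a phenyl ring carrying an amine or a carboxylic acid, or a pyridine ring, would give stronger inhibition at this place.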